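The source may hold more compounds than are shown below. What is called first, only, known or untested is meant among the compounds shown, and "the series" means these compounds.

Measured in an ADME assay on MCF-10A cells (Homo sapiens) for inhibition, with a stated time of 48 h; on this read-out lower numbers stand for stronger inhibition and higher numbers for weaker inhibition:
- compound 1 `O=C(Nc1ccc(Br)cc1)N1CCC[C@H]1c1nc(-c2ccccc2)no1`: > 50000 nM
- compound 2 `O=C(Nc1ccc(C(F)(F)F)cc1)N1CCC[C@H]1c1nc(-c2ccccc2)no1`: > 50000 nM
- compound 3 `Cc1ccccc1-c1noc([C@@H]2CCCN2C(=O)Nc2ccc(Cl)cc2)n1`: > 50000 nM

Each of these entries is a limit and not a number. Compound 3 has no readable position of its own: its entry, > 50000 nM, is a limit in this assay. The whole set offers only (the limit of > 50000 nM in this assay, at which 3 of the 3 values shown sit).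

The next compound is compound 4 `O=C(Nc1ccc(Cl)cc1)N1CCC[C@H]1c1nc(-c2cccc(Cl)c2)no1`. It carries 3-chlorophenyl in place of 2-methylphenyl on an aromatic carbon of a five-membered aromatic ring with 2 nitrogen and 1 oxygen, between two ring nitrogen atoms. The counted difference is 3-chlorophenyl in place of 2-methylphenyl on an aromatic carbon.

Within the data shown here, only one measured step links two compounds that differ in one place, and it concerns another group: a step that the two limits leave unreadable from compound 1 to compound 2, with trifluoromethyl in place of bromo on an aromatic carbon. That step gives no size to carry over, so no step beyond the scatter is expected in this assay, and no direction can be argued. A report as a limit is the most likely outcome for the next measurement.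

The expected step is a step that the limit leaves unreadable from compound 3 to compound 4, an estimate only. For compound 4 the estimated value is 55000 nM, with an expected range from 20000 nM to 100000 nM.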

Compound 4, half-maximal inhibitory concentration: > 50000 nM
Compound 4: only a limit was reported; the forecaster's own chance of this, stated with the estimate: 85%; the middle value lies beyond the limit too.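

In this assay, among these compounds, compound 4 gives > 50000 nM, which is a limit and not a number, so no step from compound 3 to compound 4 can be read. The compounds shown leave open how any of them compares with the others and what a change of group does here, for the set offers only this: the limit of > 50000 nM in this assay, at which 4 of the 4 values shown sit.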